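A few compounds are considered here, and "the series" means these few. Any claim that something is new, unique, unknown or untested is made for them only; others in the source may bear on it.

Measured compounds in an ADME assay on HeLa cells (Homo sapiens) for cytotoxicity, read by ATP content, with a stated time of 3 days; on this read-out higher numbers stand for lower toxicity in this test and lower numbers for higher toxicity in this test:
compound 1 `Cn1ccc(-n2c(=O)n(Cc3cc4cc(Cl)ccc4n3CCCC#N)c3cnccc32)n1`; compound 1 gives > 50000 nM, a limit of the test rather than a number.
compound 2 `N#CCCCn1c(Cn2c(=O)n(C3CC3)c3ccncc32)nc2nc(Cl)ccc21`; compound 2 gives > 50000 nM, also a limit.
compound 3 `O=c1n(Cc2cc3ccncc3n2CCCCO)c2cnccc2n1C1CC1`; compound 3 gives > 100000 nM, also a limit.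

Compound 1 therefore stands at a limit only, with no number to rank it against the others. Compound 1 sits at the limit of > 50000 nM in this assay, at which 2 of the 3 values shown sit. Compound 3 sits at the limit of > 100000 nM in this assay, at which 1 of the 3 values shown sits. Among the compounds with values here, no two measured compounds differ in a single place, so no measured step is available, and every value is a limit; the spread within the three values shows nothing beyond the scatter.

The next compound is compound 4 `N#CCCCn1c(Cn2c(=O)n(-c3ccc(OC(F)(F)F)cc3)c3ccncc32)cc2cc(Cl)ccc21`. It differs from compound 1 in one place: 4-(trifluoromethoxy)phenyl in place of 1-methyl-1H-pyrazol-3-yl on an aromatic nitrogen. With all three measured compounds at a limit, the expected step that the limit leaves unreadable from compound 1 to compound 4 is none beyond the scatter. Compound 4 is estimated to give 60000 nM in this assay, within 20000 nM to 200000 nM, and most likely again only a limit.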

Compound 4, half-maximal cytotoxic concentration: > 50000 nM
Compound 4: no number, only a limit; the forecaster's own chance of this, stated with the estimate: 60%; the middle value is on the limit's open side.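

Compound 1 and compound 4 both stand only at a limit in this assay, so no step can be read for 4-(trifluoromethoxy)phenyl in place of 1-methyl-1H-pyrazol-3-yl: the limit of > 50000 nM in this assay, at which 3 of the 4 values shown sit.

The compounds shown leave open at what concentration any of them reaches half-maximal cytotoxicity, and whether changing groups on the shared core alters it.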